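Sulfamoylphenyl series: estimate for the hydroxynaphthyl analogue

This account rests on a few compounds, and the source may have more. Where it says the series, first, only, none or still open, it means among the compounds named here.

Measured so far:
compound 1 `N#CC1=C(N)N(c2ccc(S(N)(=O)=O)cc2)C2=C(CCCC2)C1/C=C/c1ccccc1`, 70%
compound 2 `COc1ccccc1C1C(C#N)=C(N)N(c2ccc(S(N)(=O)=O)cc2)C2=C1CCCC2`, 100%
compound 3 `COc1ccc(C2C(C#N)=C(N)N(c3ccc(S(N)(=O)=O)cc3)C3=C2CCCC3)cc1`, 100%

All three were run in a functional assay on Ehrlich cells (Mus musculus) for cytotoxicity, read by trypan blue exclusion, with a stated time of 2 h, tested at 100 ug/mL; a higher number here means a stronger effect of the compound at the concentration tested, a lower number a weaker effect. Compound 3 stands level with compound 2 at the digits given, the two together being the highest of the three numbers; compound 1 is the furthest from it, as shown by a number 30 percentage points higher from compound 1 to compound 3 (beyond the scatter). The step of no change at the digits printed from compound 2 to compound 3 (within the scatter) shows that moving the methoxy group on the phenyl ring left the read-out unchanged.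

Compound 4 `N#CC1=C(N)N(c2ccc(S(N)(=O)=O)cc2)C2=C(CCCC2)C1c1c(O)ccc2ccccc12` is not yet measured. It differs from compound 3 in one place: 2-hydroxynaphthalen-1-yl in place of 4-methoxyphenyl on a saturated ring carbon.

Among the measured compounds shown here, two measured steps bear on this change, since both alter the group on the same saturated ring carbon: a number 30 percentage points higher from compound 1 to compound 3 (beyond the scatter) and no change at the digits printed from compound 2 to compound 3 (within the scatter). Replacing the 2-phenylethenyl by an aromatic ring carrying an oxygen raised the number, and the position of that oxygen on the ring made no difference. The 2-hydroxynaphthalen-1-yl is again an aromatic group carrying an oxygen, so compound 4 is expected to stay close to compound 3, with a step of a number 8 percentage points lower from compound 3 to compound 4 (within the scatter) within or just beyond the scatter. The expected value for compound 4 is 92%, with a range from 70% to 100%; the lower end allows for the read-out falling back toward compound 1.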

Compound 4, a percentage reported as activity, at one concentration (the size of the read-out at that concentration, not a potency): 50%
Beside the measured number, compound 4's estimate is 42 percentage points above it; the measured number lies below the stated range.
By their numbers in this assay, from the lowest: compound 4; then compound 1; then compounds 2 and 3 (each within the scatter of the next).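

At the saturated ring carbon, an aromatic group carrying an oxygen is not enough to keep the read-out in this assay high: the 2-hydroxynaphthalen-1-yl gives a number 50 percentage points lower from compound 3 to compound 4 (beyond the scatter) and a number 50 percentage points lower from compound 2 to compound 4 (beyond the scatter) as well. It also ends up under the 2-phenylethenyl, with a number 20 percentage points lower from compound 1 to compound 4 (beyond the scatter) at this position, so replacing that group does not always raise the number, and the two methoxyphenyl compounds no longer speak for aromatic groups in general. Nothing available explains the fall.

The change brings in a second aromatic ring and a hydroxyl together, so the compounds shown cannot separate the two. A 2-hydroxyphenyl or an unsubstituted naphthalen-1-yl on the same carbon would bear on that, and an aminophenyl would test a ring substituent without oxygen.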